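The source may report more compounds than this note shows. Statements on the series, on what has been measured and on what is new or still open speak of the compounds shown alone.

Measured so far in a physicochemical assay for lipophilicity, at pH 7.4; on this read-out lower numbers stand for lower lipophilicity and higher numbers for higher lipophilicity:
- compound 1 `CC(C)CN(c1ccc(C#N)cc1)S(=O)(=O)c1ccc2c(c1)C(=O)CC(C1CCOCC1)O2`: 3.16
- compound 2 `CC(C)CN(c1ccccc1F)S(=O)(=O)c1ccc2c(c1)C(=O)CC(C1CCOCC1)O2`: 3.44
- compound 3 `CCc1ccc(N(CC(C)C)S(=O)(=O)c2ccc3c(c2)C(=O)C[C@@H](C2CCOCC2)O3)cc1`: 4.2

Compound 3 stands highest of the three in this assay at 4.2, with compound 2 and compound 1 both lower, beyond the scatter.

Compound 4 `CCc1ccc(N(CC(C)C)S(=O)(=O)c2ccc3c(c2)C(=O)C[C@H](C2CCOCC2)O3)cc1` differs from compound 3 in configuration only: the two compounds have the same atoms and bonds and differ only in configuration as drawn: 1 of 1 stereo elements differ; a stereocentre at a saturated ring carbon is drawn S in compound 3 and R in compound 4. For the measured compounds named here, the one measured step, a number 0.28 log units higher from compound 1 to compound 2 (within the scatter), exchanges 4-cyanophenyl for 2-fluorophenyl on a sulfonamide nitrogen, so it offers no direct measure of a configuration change. With the same atoms and bonds, no shift beyond the scatter is expected. The expected step is no change at the digits printed from compound 3 to compound 4 (within the scatter). For compound 4 the estimated value is 4.2, with an expected range of 3.9 to 4.5.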

Compound 4, distribution coefficient: 4.24
Compound 4: middle estimate off by 0.04 log units, on the low side; the range from low to high includes it.
By their numbers in this assay, from the lowest: compounds 1 and 2 (each within the scatter of the next); then compounds 3 and 4 (each within the scatter of the next).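

At the stereocentre at a saturated ring carbon, this assay gives a number 0.04 log units higher from compound 3 to compound 4 (within the scatter). For the compounds shown here, compounds 1 and 2 are drawn without a configuration at this carbon, so only this pair reads the two drawn configurations against each other, and the comparison isolates configuration alone: the fact that compounds 3 and 4 differ only in the configuration as drawn. For this pair, S and R are not separated in this assay.

On these data alone, it remains open whether the two configurations also read alike when an amine or a carboxylic acid is carried on the aryl group at the sulfonamide nitrogen. As far as these compounds go, whether they stay alike in any other read-out is also open.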